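This account rests on a few compounds, and the source may have more. Where it says the series, first, only, none or still open, it means among the compounds named here.

Compound 1 (`COc1ccc(Br)cc1C(C)NC(=O)NS(=O)(=O)c1ccc(Cl)cc1`) gives 80900 nM
Compound 2 (`CC(C)Oc1ccc(Br)cc1C(C)NC(=O)NS(=O)(=O)c1ccccc1`) gives 143000 nM

Both values come from a functional assay on thoracic aorta (Rattus norvegicus, strain Wistar), with a stated time of 15 min (a higher number here means that more compound is needed for the effect, a lower number that less compound is needed), and lie within the usual scatter of each other, so compound 2 stands level with compound 1 on these numbers. Compound 3 (`CC(C)Oc1ccc(Br)cc1C(C)NC(=O)NS(=O)(=O)c1ccc(Cl)cc1`) is compound 2 with a single change (chloro in place of hydrogen on an aromatic carbon), chloro in place of hydrogen on an aromatic carbon, or phenyl to 4-chlorophenyl. For the measured compounds named here, no measured pair shows this change alone. Compound 1 also carries the 4-chlorophenyl and gives 80900 nM, within the scatter of compound 2. In this assay no step beyond the scatter is therefore expected, in either direction. The expected change is small, an estimated 1.4-fold lower number from compound 2 to compound 3 (0.16 log units; within the scatter). For compound 3 the estimate is 100000 nM, with an expected range of 50000 nM to 200000 nM.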

Compound 3, half-maximal effective concentration: 122000 nM
The estimate for compound 3 lay 1.2-fold (0.09 log units) below the measured number; the measured number falls inside the stated range.
By their numbers in this assay, from the lowest: compounds 1, 3 and 2 (each within the scatter of the next).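

In this assay the change from phenyl to 4-chlorophenyl can now be read directly with the isopropyl on the oxygen held constant (a 1.2-fold lower number from compound 2 to compound 3 (0.07 log units; within the scatter)), so chloro in place of hydrogen at this carbon, para to a large group, leaves the number level. For the compounds shown here, the change of methyl to isopropyl on the oxygen can also be read on its own for the first time, with the 4-chlorophenyl held constant (a 1.5-fold higher number from compound 1 to compound 3 (0.18 log units; within the scatter)). Neither change moves the number beyond the scatter among these three compounds.

The compounds shown leave open whether an amine or a carboxylic acid at this ring position, or a longer chain on the oxygen, would give a step beyond the scatter. Nothing at hand accounts for these level numbers.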